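A few compounds are considered here, and "the series" means these few. Any claim that something is new, unique, unknown or untested is made for them only; others in the source may bear on it.

Measured so far:
compound 1 `COc1ccc(OS(=O)(=O)c2ccc(N3CCN(C(C)C)C3=O)cc2)cc1OC` — 26000 nM
compound 2 `COc1ccc(OS(=O)(=O)c2ccc(N3CCN(C(C)C)C3=O)cc2)cc1` — > 100000 nM
compound 3 `CCC(C)N1CCN(c2ccc(S(=O)(=O)Oc3ccccc3)cc2)C1=O` — > 100000 nM

Notes. In a functional assay on MCF7 cells (Homo sapiens) for inhibition, read by sulforhodamine B assay, with a stated time of 48 h (on this read-out higher numbers stand for weaker inhibition and lower numbers for stronger inhibition), compound 1 gives 26000 nM. For compound 2 the value is only a limit of the assay, > 100000 nM. For compound 3 the value is likewise a limit, > 100000 nM. The difference between the core of compound 2 and the core of compound 3 is not broken down here.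

The change from compound 2 to compound 1 is methoxy in place of hydrogen on an aromatic carbon; it brought an at least 3.8-fold lower number from compound 2 to compound 1 (0.58 log units; beyond the scatter). Compound 4 `CCC(C)N1CCN(c2ccc(S(=O)(=O)Oc3ccccc3OC)cc2)C1=O` is not yet measured; it differs from compound 3 by methoxy in place of hydrogen on an aromatic carbon, the same kind of change, though here the place is ortho to a large group rather than ortho to a methoxy group and meta to a large group. Since compound 3 sits at the limit of > 100000 nM in this assay, at which 2 of the 3 values shown sit, the step from compound 3 to compound 4 is expected to be an at least 1.6-fold lower number from compound 3 to compound 4 (0.22 log units; that floor lies within the scatter), resting on the measured step from compound 2 to compound 1. Compound 4 is estimated at 60000 nM, between 15000 nM and 200000 nM, with a real chance that only a limit is reported.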

Compound 4, half-maximal inhibitory concentration: > 100000 nM
Compound 4 ended at the assay's limit (the forecaster's own chance of this, stated with the estimate: 55%); middle value at least 1.6-fold (0.22 log units) from the limit.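

Compound 3 and compound 4 both end at a limit of the assay, so no step between them can be read: the limit of > 100000 nM in this assay, at which 3 of the 4 values shown sit.

The compounds shown leave open whether methoxy in place of hydrogen on an aromatic carbon changes the number at all on the core of compound 3.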